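Dropping one trifluoromethyl from a bis-trifluoromethyl urea

A few compounds are considered here, and "the series" means these few. Any claim that something is new, unique, unknown or untested is made for them only; others in the source may bear on it.

Measured compounds:
compound 1 `COc1cc(Cl)cc(-c2nn(-c3cccc(NC(=O)c4ccc(Cl)c(Cl)c4)c3)cc2-c2ccncc2)c1` — 63.6%
compound 2 `COc1cc(Cl)cc(-c2nn(-c3cccc(NC(=O)Nc4cc(C(F)(F)F)cc(C(F)(F)F)c4)c3)cc2-c2ccncc2)c1` — 5.82%

Both compounds were tested in a functional assay on Hs-578T cells (Homo sapiens) for inhibition, read by sulforhodamine B assay, with a stated time of 48 h, tested at 10 uM; on this read-out lower numbers stand for a stronger effect and higher numbers for a weaker effect at the one concentration tested. Compound 1 gives 63.6%, while compound 2 gives 5.82%, the lower of the two numbers and thus the stronger effect. The gap between them is far beyond the scatter of repeated measurements, so compound 2 clearly stands apart from compound 1.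

Compound 3 `COc1cc(Cl)cc(-c2nn(-c3cccc(NC(=O)Nc4cccc(C(F)(F)F)c4)c3)cc2-c2ccncc2)c1` has not yet been measured. It differs from compound 2 in one place: hydrogen in place of trifluoromethyl on an aromatic carbon. The change sits on the urea-bearing ring of compound 2, and the rest of the shared core is untouched.

Because compound 2 gives 5.82%, the strong effect is expected to be partly kept; still, losing one trifluoromethyl is expected to weaken it, with a step of a number 14.2 percentage points higher from compound 2 to compound 3 (beyond the scatter) estimated in this assay. Compound 3 is therefore estimated at 20%, within a range from 5% to 50%.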

Compound 3, a percentage reported as activity, at one concentration (the size of the read-out at that concentration, not a potency): 23.2%
The estimate for compound 3 lay 3.2 percentage points below the measured number; measured number inside the range.
By their numbers in this assay, from the lowest: compound 2; then compound 3; then compound 1.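

In this assay, the change of trifluoromethyl to hydrogen gives a number 17.4 percentage points higher from compound 2 to compound 3 (beyond the scatter), a modest step: this position on the urea-bearing ring matters, yet part of the effect survives with one trifluoromethyl left. The change from 3,4-dichlorophenyl to (3-(trifluoromethyl)phenyl)amino on the carbonyl carbon gives a number 40.4 percentage points lower from compound 1 to compound 3 (beyond the scatter), a large step, so the urea with a single trifluoromethyl still acts clearly more strongly than the compound without a urea. Nothing available here explains either step.

On these data alone, whether the effect at this position needs trifluoromethyl itself remains open, since a nitrile or an amine on that same aromatic carbon could tell. It also remains open how the trifluoromethyl that was kept in compound 3 contributes on its own, as no urea without any trifluoromethyl is shown.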